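A few compounds are considered here, and "the series" means these few. Any claim that something is new, unique, unknown or untested is made for them only; others in the source may bear on it.

Working notes on the series. Compound 1 `O=C1C[C@H](OCc2cn(Cc3ccccc3)nn2)[C@H]2CO[C@@H]1O2`, compound 2 `O=C1C[C@H](OCc2cc(-c3ccccc3)no2)[C@H]2CO[C@@H]1O2` and compound 3 `O=C1C[C@H](OCc2cc(-c3ccc([N+](=O)[O-])cc3)no2)[C@H]2CO[C@@H]1O2` share one core and differ only in the aromatic portion attached through the ether-linked methylene. In a functional assay on MDA-MB-231 cells (Homo sapiens) for cytotoxicity, read by MTT assay, with a stated time of 48 h (a lower number here means a stronger inhibitor, a higher number a weaker inhibitor), compound 1 gives > 50000 nM, which is a limit of the assay rather than a number; this is the limit of > 50000 nM in this assay, at which 1 of the 3 values shown sits. In this assay compound 2 gives 21900 nM. In this assay compound 3 gives 16500 nM. For the measured compounds named here, the single one-place step measured so far is a 1.3-fold lower number from compound 2 to compound 3 (0.12 log units; within the scatter), so of the two numbers in hand compound 3 holds the lower one, with compound 2 nearest and within the scatter of it.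

Compound 4 `O=C1C[C@H](OCc2cc(-c3ccc(Cl)cc3)no2)[C@H]2CO[C@@H]1O2` has not yet been measured. It differs from compound 3 by chloro in place of nitro on an aromatic carbon. Going by the values given here, the only measured step at this position, a 1.3-fold lower number from compound 2 to compound 3 (0.12 log units; within the scatter), did not move the number beyond the scatter, and the exchange of nitro for chloro has no measured precedent. The expected step in this assay is therefore about a 1.1-fold higher number from compound 3 to compound 4 (0.04 log units; within the scatter), which is no change beyond the scatter. Compound 4 is estimated at 18000 nM, with a range from 8000 nM to 45000 nM.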

Compound 4, half-maximal inhibitory concentration: 17900 nM
Beside the measured number, compound 4's estimate is 1.0-fold (0.00 log units) above it, within the range that was stated.
By their numbers in this assay, from the lowest: compounds 3, 4 and 2 (each within the scatter of the next). At a limit, above all of these: compound 1.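

In this assay two different replacements on this aromatic carbon can now be read, and neither leaves the scatter: (a 1.1-fold higher number from compound 3 to compound 4 (0.04 log units; within the scatter)) for chloro in place of nitro and (a 1.2-fold lower number from compound 2 to compound 4 (0.09 log units; within the scatter)) for chloro in place of hydrogen. For the compounds shown here, compound 3 had so far given only one such comparison, whereas hydrogen, nitro and chloro, para to a large group, now form a set of three in which compound 2, compound 3 and compound 4 cannot be told apart, even though the exchange of nitro for chloro removes 2 hydrogen-bond acceptors and a double bond outside aromatic rings. Going by these compounds alone, compound 1 remains the only compound at a limit, and compound 4 adds none: the limit of > 50000 nM in this assay, at which 1 of the 4 values shown sits.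

On these data alone, whether a group of another kind at this place, such as an amine or a carboxylic acid, would move the number beyond the scatter stays open. The same holds for a longer chain in place of chloro, and the compounds shown give no cause for the absence of a change among these three groups.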